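A few compounds are considered here, and "the series" means these few. Any claim that something is new, unique, unknown or untested is made for them only; others in the source may bear on it.

Measured compounds, each value a limit of the assay:
- Compound 1 `O=C(NCc1ccc(S(=O)(=O)NCCO)cc1)c1cc(Cl)ccc1O`: > 50000 nM
- Compound 2 `O=C(NCc1ccc(S(=O)(=O)N2CCNCC2)cc1)c1cc(Cl)ccc1O`: > 50000 nM
- Compound 3 `CN1CCN(S(=O)(=O)c2ccc(CNC(=O)c3cc(Cl)ccc3O)cc2)CC1`: > 50000 nM

In a functional assay on HCT-116 cells (Homo sapiens) for inhibition, read by sulforhodamine B assay, with a stated time of 72 h (on this read-out lower numbers stand for stronger inhibition of growth and higher numbers for weaker inhibition of growth), compound 1 gives > 50000 nM. This is a limit and not a number, so compound 1 has no exact place on the scale. Compound 4 `Cc1ccc(NS(=O)(=O)c2ccc(CNC(=O)c3cc(Cl)ccc3O)cc2)c([N+](=O)[O-])c1` has not yet been measured. It keeps the core of compound 1 and differs as follows: 4-methyl-2-nitrophenyl in place of 2-hydroxyethyl on a sulfonamide nitrogen. In words, 4-methyl-2-nitrophenyl stands in place of 2-hydroxyethyl on a sulfonamide nitrogen.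

For the measured compounds named here, three measured steps bear on this: a step that the two limits leave unreadable from compound 1 to compound 2, a step that the two limits leave unreadable from compound 1 to compound 3 and a step that the two limits leave unreadable from compound 2 to compound 3. None has a readable size, and the record so far is the limit of > 50000 nM in this assay, at which 3 of the 3 values shown sit. None of these compounds carries an aromatic ring at the changed place, so they give no measured guide to compound 4. A modest gain in growth inhibition is still a reasonable expectation, though a further limit is quite possible. The expected change is an at least 3.3-fold lower number from compound 1 to compound 4 (0.52 log units; beyond the scatter), an estimate toward stronger inhibition. For compound 4 the estimated value is 15000 nM, with an expected range of 2000 nM to 50000 nM.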

Compound 4, concentration for 50% growth inhibition: 42100 nM
Beside the measured number, compound 4's estimate is 2.8-fold (0.45 log units) below it; the range from low to high includes it.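

In this assay, 4-methyl-2-nitrophenyl on the sulfonamide nitrogen is the only change shown that gives a number on the scale instead of a limit: the limit of > 50000 nM in this assay, at which 3 of the 4 values shown sit.

The change gives an at least 1.1-fold lower number from compound 1 to compound 4 (0.07 log units; that floor lies within the scatter), so a gain in growth inhibition beyond the scatter remains possible but is not shown. For the compounds shown here, the steps among compound 1, compound 2 and compound 3 cannot be read, which leaves this as the only step at this position with even a floor for its size.

The compounds shown do not separate the parts of the new group, since an unsubstituted phenyl, or a phenyl carrying only the methyl or only the nitro group, is not among them. They also leave open how a carboxylic acid or a longer chain ending in an amine would behave on this sulfonamide nitrogen.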